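The source may hold more compounds than are shown below. What is called first, only, known or untested is meant among the compounds shown, and "the series" means these compounds.

In a functional assay on MCF7 cells (Homo sapiens) for cytotoxicity, read by sulforhodamine B assay, with a stated time of 3 days (on this read-out lower numbers stand for stronger inhibition and higher numbers for weaker inhibition), compound 2 `O=[N+]([O-])c1ccc(S(=O)(=O)N2CC(n3cnc4c(Cl)nc(Cl)nc43)OCc3ccccc32)cc1` gives 355 nM, the lowest of the two numbers recorded. Compound 1 `O=[N+]([O-])c1ccccc1S(=O)(=O)N1CC(n2cnc3c(Br)ncnc32)OCc2ccccc21` gives 3620 nM, a higher number in this assay, beyond the scatter. Compound 3 `O=[N+]([O-])c1ccc(S(=O)(=O)N2CC(n3cnc4c(Br)ncnc43)OCc3ccccc32)cc1` differs from compound 2 by a group of 10 heavy atoms (5 carbon, 4 nitrogen, 1 bromine; one five-membered aromatic ring with 2 hetero atoms, one six-membered aromatic ring with 2 hetero atoms) in place of a group of 11 heavy atoms (5 carbon, 4 nitrogen, 2 chlorine; one five-membered aromatic ring with 2 hetero atoms, one six-membered aromatic ring with 2 hetero atoms), on a saturated ring carbon. Going by the values given here, no measured pair isolates this change, so the account can only weigh the two numbers known. A moderate loss of potency is expected, the step from compound 2 to compound 3 being estimated at a 4.2-fold higher number from compound 2 to compound 3 (0.63 log units; beyond the scatter). Compound 3 is therefore expected to give about 1500 nM in this assay, within a range from 500 nM to 5000 nM.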

Compound 3, half-maximal inhibitory concentration: 1230 nM
The estimate for compound 3 lay 1.2-fold (0.09 log units) above the measured number, within the range that was stated.
By their numbers in this assay, from the lowest: compound 2; then compound 3; then compound 1.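

In this assay, compound 3 joins the two earlier compounds through single changes. The group with one bromine in place of the group with two chlorine atoms, on the saturated ring carbon, gives a 3.5-fold higher number from compound 2 to compound 3 (0.54 log units; beyond the scatter), while 4-nitrophenyl in place of 2-nitrophenyl on the sulfonyl sulfur gives a 2.9-fold lower number from compound 1 to compound 3 (0.47 log units; beyond the scatter), so both changes contribute to the gap between compound 1 and compound 2. Nothing at hand offers a reason for either step.

From the compounds shown here alone, it remains open how an amine in place of the bromine would compare with compound 3, and how a 4-aminophenyl on the sulfonyl sulfur would compare with its 4-nitrophenyl.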